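The source may report more compounds than this note shows. Statements on the series, on what has been measured and on what is new or still open speak of the compounds shown alone.

Of the compounds shown here, three built on a shared core have been measured in a functional assay on HeLa cells (Homo sapiens) for cytotoxicity, read by MTT assay, with a stated time of 48 h; on this read-out higher numbers stand for weaker inhibition and lower numbers for stronger inhibition. Compound 1 `O=C1C(O)=C(C(c2ccc(F)cc2)c2c[nH]c3ccccc23)C(=O)c2ccccc21` gives 15800 nM, compound 2 `Cc1[nH]c2ccccc2c1C(C1=C(O)C(=O)c2ccccc2C1=O)c1ccc(Cl)cc1` gives 8030 nM, and compound 3 `O=C1C(O)=C(C(c2ccc([N+](=O)[O-])cc2)c2c[nH]c3ccccc23)C(=O)c2ccccc21` gives 14800 nM. Among these three numbers compound 3 stands second highest; its nearest neighbour is compound 1, and the gap to compound 2 is also within the scatter, so none of the three can be told apart with confidence. Within the data shown here, the one change measured on its own, a 1.1-fold lower number from compound 1 to compound 3 (0.03 log units; within the scatter), swapped the group on the outer aromatic ring and left the number where it was.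

Compound 4 `Cc1[nH]c2ccccc2c1C(C1=C(O)C(=O)c2ccccc2C1=O)c1ccc([N+](=O)[O-])cc1` is the next step: methyl in place of hydrogen on an aromatic carbon. Among the measured compounds shown here, no measured pair differs by this methyl alone. Compound 2 carries it while compound 1 and compound 3 do not, but compound 2 also carries a different group on the other aromatic ring, and all three numbers sit within the scatter of one another. On this basis the methyl is expected to produce in compound 4 a step of a 1.5-fold lower number from compound 3 to compound 4 (0.17 log units; within the scatter), meaning a small shift toward a lower number at most. Compound 4 is therefore estimated to give 10000 nM in this assay, with a range from 4000 nM to 25000 nM.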

Compound 4, half-maximal inhibitory concentration: 4570 nM
The estimate for compound 4 lay 2.2-fold (0.34 log units) above the measured number, and the stated range covers the measured number.
By their numbers in this assay, from the lowest: compounds 4, 2, 3 and 1 (each within the scatter of the next, the first and the last beyond it).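

Among these compounds, the methyl on the aromatic carbon next to the ring nitrogen, the change from 1H-indol-3-yl to 2-methyl-1H-indol-3-yl, can now be read on its own: in this assay it gives a 3.2-fold lower number from compound 3 to compound 4 (0.51 log units; beyond the scatter), the first single change in this set to stand clear of the usual scatter. Swapping the other group does not do this, either with the methyl present, a 1.8-fold lower number from compound 2 to compound 4 (0.24 log units; within the scatter), or without it, a 1.1-fold lower number from compound 1 to compound 3 (0.03 log units; within the scatter), so in both of these pairs the compounds cannot be told apart, and among the single changes shown only the methyl moves the number measurably. Nothing available explains how this methyl lowers the number in this assay.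

From the compounds shown here alone, the methyl step rests on a single pair that carries a nitro group, so whether it holds alongside a fluoro or chloro group stays open. Also open, going by these compounds, is how the number would respond at this same place to a longer chain such as ethyl, or to an amine.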